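Replacing a Carbonyl-Linked Piperazine with an Ether-Linked Piperidine

This account rests on a few compounds, and the source may have more. Where it says the series, first, only, none or still open, it means among the compounds named here.

Compound 2 `COc1ccc(N2CCc3ncnc(-c4cccc(C(=O)N5CCN(C(C)=O)CC5)c4)c3C2)cn1` was examined in an ADME assay on microsomes from liver (Rattus norvegicus) for metabolic stability (on this read-out lower numbers stand for slow clearance and higher numbers for fast clearance), where compound 2 gave 91 uL/min. For the measured compounds named here, the only other measured member of the set, compound 1 `COc1ncc(N2CCc3ncnc(O[C@H]4CCN(C(=O)C5CCOCC5)C4)c3C2)cc1C`, gave 60 uL/min in this assay; the two numbers lie within the usual scatter of each other. Compound 3 `COc1ccc(N2CCc3ncnc(-c4cccc(OC5CCN(C(C)=O)CC5)c4)c3C2)cn1` has not yet been measured in this assay. It differs from compound 2 in one place: (1-acetylpiperidin-4-yl)oxy in place of (4-acetylpiperazin-1-yl)carbonyl on an aromatic carbon. Going by the values given here, no measured pair shows the effect of this change, so the author expects the step of a 1.0-fold lower number from compound 2 to compound 3 (0.00 log units; within the scatter) to stay within the scatter. Compound 3 is therefore estimated at 90 uL/min, with a range from 45 uL/min to 180 uL/min.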

Compound 3, intrinsic clearance in a liver preparation (reported as CLH), per the amount of preparation that the assay uses in the Rattus norvegicus assay: 197 uL/min
Beside the measured number, compound 3's estimate is 2.2-fold (0.34 log units) below it; measured number outside the range, above it.
By their numbers in the Rattus norvegicus assay, from the lowest: compounds 1 and 2 (each within the scatter of the next); then compound 3.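

In the Rattus norvegicus assay the change from (4-acetylpiperazin-1-yl)carbonyl to (1-acetylpiperidin-4-yl)oxy on an aromatic carbon gives the first step read at this position: a 2.2-fold higher number from compound 2 to compound 3 (0.34 log units; beyond the scatter) lies beyond the scatter. In a physicochemical assay for solubility, read by LC-MS, measured as thermodynamic solubility, at pH 6.8 (a higher number here means a more soluble compound, a lower number a less soluble compound), compound 2 gives > 1000000 nM, which is a limit of the assay. In the physicochemical assay compound 3 gives > 1000000 nM, again a limit.

No step can be read between these two values, because of this limit: the limit of > 1000000 nM in the physicochemical assay, at which 2 of the 2 values shown sit. On these data alone, whether a methylene or an amine link in place of the ether oxygen would also give the higher number stays open.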